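The source may hold more compounds than are shown below. What is called first, only, known or untested is meant among the compounds shown, and "the series" means these compounds.

Of the compounds shown here, three of a shared core have been measured in a functional assay for agonist activity at G protein-coupled receptor 88 (Homo sapiens), read by HTRF and cAMP accumulation; on this read-out lower numbers stand for an effect already at smaller amounts and higher numbers for an effect only at larger amounts of compound. Compound 1 `CC(C)C[C@H](N)CN(C(=O)[C@@H]1C[C@H]1c1ccccc1)c1ccc(-c2ccccc2)cc1` gives 880 nM. Within the data shown here, compound 2 `CCC(C)CNCCN(C(=O)[C@@H]1C[C@H]1c1ccccc1)c1ccc(-c2ccccc2)cc1`, which carries ((2-methylbutyl)amino)methyl in place of 1-amino-3-methylbutyl on a saturated chain carbon bound to an amide-type nitrogen, gives 4.7 nM, and the step of a 190-fold lower number from compound 1 to compound 2 (2.27 log units; beyond the scatter) is the only single-change step among the measured compounds. Compound 3 `CC[C@H](C)[C@H](N)CN(C(=O)[C@@H]1C[C@H]1c1cccc(F)c1)c1ccc(-c2ccccc2)cc1` gives 560 nM; it stands second highest of the three numbers, close to compound 1 within the scatter, and far from compound 2 beyond the scatter.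

Compound 4 `CC[C@H](C)[C@H](N)CN(C(=O)[C@@H]1C[C@H]1c1ccoc1)c1ccc(-c2ccccc2)cc1` has not yet been measured. It differs from compound 3 in one place: furan-3-yl in place of 3-fluorophenyl on a saturated ring carbon. Among the measured compounds shown here, no measured step touches this part of the structure; the one measured step concerns the amine-bearing chain, not the group on the three-membered ring, so it gives no direct guide to the size or direction of the change from a 3-fluorophenyl to a furan-3-yl. For the measured compounds named here, with no comparable step to draw on, a modest change is expected rather than a large one. The step from compound 3 to compound 4 is therefore estimated as a 1.4-fold higher number from compound 3 to compound 4 (0.15 log units; within the scatter). Compound 4 is expected to give 800 nM, within a range from 200 nM to 3200 nM.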

Compound 4, half-maximal effective concentration: 580 nM
Beside the measured number, compound 4's estimate is 1.4-fold (0.14 log units) above it; measured number inside the range.
By their numbers in this assay, from the lowest: compound 2; then compounds 3, 4 and 1 (each within the scatter of the next).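

Among these compounds, the only step measured at this position, a 1.0-fold higher number from compound 3 to compound 4 (0.02 log units; within the scatter), in this assay, shows that furan-3-yl can take the place of 3-fluorophenyl on the saturated ring carbon with no change beyond the usual scatter. The read-out therefore does not separate a six-membered aromatic ring of carbon only from a five-membered aromatic ring with 1 hetero atom and 1 hydrogen-bond acceptor, at least with the amine-bearing chain that compound 3 and compound 4 share. Nothing available here explains why this exchange leaves the number where it stands.

As far as these compounds go, it remains open whether furan-3-yl would behave the same way alongside the ((2-methylbutyl)amino)methyl group of compound 2, which gives 4.7 nM, since both ring groups in this step were read only on the other chain. Also open, from the compounds shown here alone, is how other groups would fare on the same ring carbon, for example thiophen-3-yl, pyridin-3-yl or cyclohexyl, and whether the result would hold for a furan-2-yl group.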